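Swapping the dichlorophenyl for a difluorophenyl ketone

The source may report more compounds than this note shows. Statements on the series, on what has been measured and on what is new or still open speak of the compounds shown alone.

Of the compounds shown here, two have been tested in a functional assay on OVCAR-5 cells (Homo sapiens) for cytotoxicity, read by sulforhodamine B assay, with a stated time of 48 h, tested at 100 uM; on this read-out lower numbers stand for a stronger effect and higher numbers for a weaker effect at the one concentration tested. Compound 1, with the structure `COc1ccc(-c2cc(/C=C/C(=O)c3ccc(N)cc3)[nH]n2)cc1`, gives -86% in this assay. Compound 2, with the structure `COc1cc(-c2cc(/C=C/C(=O)c3ccc(Cl)c(Cl)c3)[nH]n2)cc(OC)c1OC`, gives 16%. Of the two numbers, compound 2 has the higher one, and the gap to compound 1 is far beyond the scatter, so on this read-out compound 2 is the weaker of the pair.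

The next compound, compound 3, has the structure `COc1cc(-c2cc(/C=C/C(=O)c3ccc(F)c(F)c3)[nH]n2)cc(OC)c1OC`. It differs from compound 2 in one place: 3,4-difluorophenyl in place of 3,4-dichlorophenyl on a carbonyl carbon. Among the compounds with values here, the only halogenated aryl ketone measured so far is that of compound 2, and no measured pair shows what exchanging a 3,4-dichlorophenyl for a 3,4-difluorophenyl on a carbonyl carbon does in this assay.

Without such a comparison, the expected step from compound 2 to compound 3 in this assay is a number 11 percentage points lower from compound 2 to compound 3 (beyond the scatter), which is small and may well stay within the scatter. Compound 3 is therefore expected to give about 5% in this assay, plausibly anywhere from -50% to 35%.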

Compound 3, a percentage reported as activity, at one concentration (the size of the read-out at that concentration, not a potency): -24%
Compound 3: middle estimate off by 29 percentage points, on the high side, within the range that was stated.
By their numbers in this assay, from the lowest: compound 1; then compound 3; then compound 2.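

Within the data shown here, replacing 3,4-dichlorophenyl with 3,4-difluorophenyl on a carbonyl carbon gives the first single-place comparison, and in this assay it produces a number 40 percentage points lower from compound 2 to compound 3 (beyond the scatter), a large step. The read-out at this position therefore depends on which halogen the ring carries, since both groups have the same heavy-atom count, the same six-membered aromatic ring of carbon only, no hydrogen-bond donors or acceptors, and no net charge. Nothing measured here accounts for the size of this step, so it stands as an observation without an established cause.

The compounds shown leave open how other groups on this carbonyl carbon would compare, such as an unsubstituted phenyl, a 3,4-dibromophenyl or a 3,4-dimethoxyphenyl, and so whether the trend follows the halogen in any regular way. They also leave open whether the same exchange would give a step of similar size on a different core, as compound 1 differs from compound 2 and compound 3 in more than one place and cannot settle that question.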